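The compounds below may be only part of what the source reports. "The series", "measured", "known", "first", "only" and "open" are said of these compounds alone.

Measured so far:
compound 1 `O=C(Nc1ccc(Br)cc1)Nc1nc(-c2cc3ccccc3o2)cs1` — > 200000 nM
compound 2 `O=C(Nc1ccc([N+](=O)[O-])cc1)Nc1nc(-c2cc3ccccc3o2)cs1` — 19300 nM
compound 3 `O=C(Nc1ccc(F)cc1)Nc1nc(-c2cc3cc(Br)ccc3o2)cs1` — > 200000 nM

In a physicochemical assay, with a stated time of 6 min (a higher number here means a weaker inhibitor, a lower number a stronger inhibitor), compound 1 reaches only a limit, > 200000 nM. Compound 2 gives 19300 nM. The change between them, (nitro in place of bromo on an aromatic carbon), made a step of an at least 10-fold lower number from compound 1 to compound 2 (1.01 log units; beyond the scatter). Compound 3 also sits at a limit, > 200000 nM; the difference between its core and that of compound 1 is not broken down here. Compound 4 `O=C(Nc1ccc(F)cc1)Nc1nc(-c2cc3cc([N+](=O)[O-])ccc3o2)cs1` is unmeasured; it arises from compound 3 by nitro in place of bromo on an aromatic carbon, the same kind of change as before, but now on a ring that is part of a fused system, meta and para to the fused ring, rather than para to a large group. Because an at least 10-fold lower number from compound 1 to compound 2 (1.01 log units; beyond the scatter) was large, a step of about an at least 3.3-fold lower number from compound 3 to compound 4 (0.52 log units; beyond the scatter) in this assay is expected, though it starts from a limit, and compound 4 is estimated at 60000 nM.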

Compound 4, half-maximal inhibitory concentration: 123000 nM
Beside the measured number, compound 4's estimate is 2.1-fold (0.31 log units) below it; low and high end bracket the measured number.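

In this assay, nitro in place of bromo on an aromatic carbon, carried to the core of compound 3, gives an at least 1.6-fold lower number from compound 3 to compound 4 (0.21 log units; that floor lies within the scatter). This runs in the same direction as an at least 10-fold lower number from compound 1 to compound 2 (1.01 log units; beyond the scatter), but it does not show that the change lowers the number beyond the scatter on this second core, or that it acts equally on both cores. Compound 3 stands at > 200000 nM, a limit and not a number, which leaves the true size of its step unknown: the limit of > 200000 nM in this assay, at which 2 of the 4 values shown sit.

The compounds shown leave open whether the change carries over when the starting value is a measured number. They also leave open how an amine or a carboxylic acid would compare with nitro in that place.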